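The compounds below may be only part of what the source reports. "The series", "measured", "known", "first", "only" and "open" are said of these compounds alone.

Of the compounds shown here, three sharing one core have been tested so far. Compound 1 `O=C(Nc1ccc(Cl)c(-c2nnc3c(Cl)cccn23)c1)c1ccccn1` carries a pyridin-2-yl on the carbonyl carbon of the amide. In a functional assay on A549 cells (Homo sapiens) for antiproliferative activity, read by MTT assay, with a stated time of 72 h (on this read-out lower numbers stand for stronger inhibition and higher numbers for weaker inhibition), compound 1 gives only a limit, > 100000 nM, and no number. Compound 2 `O=C(Nc1ccc(Cl)c(-c2nnc3c(Cl)cccn23)c1)c1cccc(Cl)c1` carries a 3-chlorophenyl at the same place and in this assay gives 52700 nM. Compound 3 `O=C(Nc1ccc(Cl)c(-c2nnc3c(Cl)cccn23)c1)c1c(F)cccc1Cl` carries a 2-chloro-6-fluorophenyl there and in this assay gives 72300 nM, the highest of the two numbers reported; its nearest neighbour is compound 2, and the step of a 1.4-fold higher number from compound 2 to compound 3 (0.14 log units; within the scatter) lies within the scatter. Among the measured compounds shown here, the steps of an at least 1.8-fold lower number from compound 1 to compound 2 (0.27 log units; that floor lies within the scatter) and an at least 1.3-fold lower number from compound 1 to compound 3 (0.14 log units; that floor lies within the scatter) rest on the limit of > 100000 nM in this assay, at which 1 of the 3 values shown sits, and tell only that a phenyl-type group on the carbonyl carbon brings the number into the measurable range.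

Compound 4 `CS(=O)(=O)c1cccc(C(=O)Nc2ccc(Cl)c(-c3nnc4c(Cl)cccn34)c2)c1` differs from compound 3 in one place: 3-(methylsulfonyl)phenyl in place of 2-chloro-6-fluorophenyl on a carbonyl carbon. Among the measured steps, only the exchange of one substituted phenyl for another between compound 2 and compound 3 bears on this change, and it stayed within the scatter. The expectation is therefore a step of a 1.1-fold higher number from compound 3 to compound 4 (0.04 log units; within the scatter) in this assay, that is no change beyond the scatter, with a real chance that only a limit is returned. Compound 4 is estimated at 80000 nM, within a range from 30000 nM to 200000 nM.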

Compound 4, half-maximal inhibitory concentration: > 100000 nM
Compound 4 ended at the assay's limit; the forecaster's own chance of this, stated with the estimate: 35%; middle value at least 1.2-fold (0.09 log units) from the limit.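

With the 3-(methylsulfonyl)phenyl on the carbonyl carbon, compound 4 is a limit and not a number, so a phenyl-type group at this place does not by itself bring the value into the measurable range of this assay, as compound 2 and compound 3 had suggested. Exchanging either earlier phenyl group gives only floors, an at least 1.3-fold higher number from compound 3 to compound 4 (0.14 log units; that floor lies within the scatter) and an at least 1.8-fold higher number from compound 2 to compound 4 (0.27 log units; that floor lies within the scatter), the second being methylsulfonyl in place of chloro on an aromatic carbon, so neither exchange is shown to cost activity beyond the scatter. The step between compound 1 and compound 4 cannot be read, and the pyridin-2-yl and the 3-(methylsulfonyl)phenyl now stand together at the limit: the limit of > 100000 nM in this assay, at which 2 of the 4 values shown sit.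

From the compounds shown here alone, it remains open whether an amine, a carboxylic acid or a longer chain on the phenyl ring at this place would give a number in this assay, and whether that number would differ from those of compound 2 and compound 3 by more than the scatter. Going by these compounds, the true values of compound 1 and compound 4 also remain unknown, so the order of these two compounds is open.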